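Ethyl for pyrazolyl on the amide nitrogen of the series

This account rests on a few compounds, and the source may have more. Where it says the series, first, only, none or still open, it means among the compounds named here.

Two compounds of this series have numbers in an assay on HEK293 cells for agonist activity at transient receptor potential cation channel subfamily M member 8 (Homo sapiens), read by fluorescence and calcium flux, with a stated time of 15 min (on this read-out lower numbers stand for an effect already at smaller amounts and higher numbers for an effect only at larger amounts of compound), so far. Compound 2 `COc1ccc2oc(C(=O)N(Cc3cccs3)c3ccn[nH]3)cc2c1` gives 1.1 nM, the lowest of the two values. Compound 1 `CCN(Cc1cccs1)C(=O)c1cc2cc(C)ccc2o1`, which also carries ethyl on the amide-type nitrogen, gives 120 nM, a value set well apart from that of compound 2 and beyond the usual scatter. For the measured compounds named here, no step between measured compounds that differ in one place is available, so the weight of any single change is not yet known from the data.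

Compound 3 `CCN(Cc1cccs1)C(=O)c1cc2cc(OC)ccc2o1` is not yet measured. Against compound 2 it shows (ethyl in place of 1H-pyrazol-5-yl on an amide-type nitrogen). Going by the values given here, compound 1, the only other measured compound, bears the same ethyl group on the amide-type nitrogen and sits far above compound 2 in this assay; this is the only anchor for what to expect, because compound 1 gives 120 nM, the one value with ethyl at that place. The expectation for compound 3 is therefore a large step towards higher numbers, a 73-fold higher number from compound 2 to compound 3 (1.86 log units; beyond the scatter), with the estimate for compound 3 in this assay put at 80 nM, within a range from 20 nM to 400 nM.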

Compound 3, half-maximal effective concentration: 80 nM
Estimate against measurement, compound 3: no gap at the digits printed, and the stated range covers the measured number.
By their numbers in this assay, from the lowest: compound 2; then compounds 3 and 1 (each within the scatter of the next).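

In this assay the exchange on the amide-type nitrogen can now be read as a single change: ethyl in place of 1H-pyrazol-5-yl gives a 73-fold higher number from compound 2 to compound 3 (1.86 log units; beyond the scatter), so this position alone carries a large step on the methoxy-bearing core. The other single change, methoxy in place of methyl on an aromatic carbon, gives a 1.5-fold lower number from compound 1 to compound 3 (0.18 log units; within the scatter), which lies within the scatter and so shows no readable difference at that place while ethyl sits on the nitrogen. No measurement bears on the origin of the large step at the amide-type nitrogen.

Open at that nitrogen is whether the low number follows the aromatic ring or its hydrogen-bond donor, a question that a 1-methylpyrazolyl, phenyl or plain propyl group there would help to separate. Also open, from the compounds shown here alone, is whether the methyl and methoxy forms stay within the scatter of each other with 1H-pyrazol-5-yl on the nitrogen, and how a chloro or hydroxy group would behave on that aromatic carbon.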